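A few compounds are considered here, and "the series" means these few. Any claim that something is new, unique, unknown or untested is made for them only; others in the source may bear on it.

Measured so far, in a functional assay on PRK cells (Oryctolagus cuniculus) for cytotoxicity; on this read-out lower numbers stand for higher toxicity in this test and higher numbers for lower toxicity in this test:
compound 1 `CCCCCCCCOC(=O)C(O)Cn1cnc2c(N)ncnc21` gives 100 ug/mL;
compound 2 `CCCCOC(=O)C(O)Cn1cnc2c(N)ncnc21` gives 200 ug/mL;
compound 3 `CCCOC(=O)C(O)Cn1cnc2c(N)ncnc21` gives 100 ug/mL.

Compound 2 sits among these three without any step to it beyond the scatter: a 2.0-fold higher number from compound 1 to compound 2 (0.30 log units; within the scatter) and a 2.0-fold lower number from compound 2 to compound 3 (0.30 log units; within the scatter) are both small, and so is no change at the digits printed from compound 1 to compound 3 (within the scatter). The three measured compounds thus show that lengthening or shortening the chain on the ester side leaves the read-out in this assay essentially unchanged.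

Compound 4 `CC(C)COC(=O)C(O)Cn1cnc2c(N)ncnc21` is the next compound to be tested. It differs from compound 2 by isopropyl in place of propyl on a saturated chain carbon bound to an oxygen next to a carbonyl group. Among the compounds with values here, this is a rearrangement of the same chain rather than a change in its length, so none of the measured steps matches it exactly; the steps that bear on it are the three chain-length steps, all within the scatter. Since every change at this part of the molecule so far left the number where it was, the step from compound 2 to compound 4 is expected to be none beyond the scatter, that is no change at the digits printed from compound 2 to compound 4 (within the scatter). For compound 4, the estimate in this assay is 200 ug/mL, with a range from 100 ug/mL to 400 ug/mL.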

Compound 4, minimum cytotoxic concentration: > 400 ug/mL
Compound 4: only a limit was reported (the forecaster's own chance of this, stated with the estimate: 15%); middle value at least 2.0-fold (0.30 log units) away from the limit.
By their numbers in this assay, from the lowest: compounds 1, 3 and 2 (each within the scatter of the next). At a limit, above all of these: compound 4.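

In this assay, compound 4 is reported only as a limit, not as a number: the limit of > 400 ug/mL in this assay, at which 1 of the 4 values shown sits.

Within the data shown here, the isobutyl ester gives the only steps at this position that pass the scatter, an at least 4.0-fold higher number from compound 3 to compound 4 (0.60 log units; beyond the scatter) and an at least 4.0-fold higher number from compound 1 to compound 4 (0.60 log units; beyond the scatter), so on this read-out it shows lower toxicity in this test than those two straight-chain esters, while the steps among the straight chains stayed within the scatter. The closest comparison, butyl to isobutyl with the same atoms joined differently, is an at least 2.0-fold higher number from compound 2 to compound 4 (0.30 log units; that floor lies within the scatter), so this floor alone does not separate the pair, although the true step may be larger.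

As far as these compounds go, the true number for compound 4 remains open, and with it the size of that step. Also open, from the compounds shown here alone, is how a tert-butyl or isopentyl ester would read in this assay.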